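Swapping Phenyl for 3-Hydroxypropyl on Compound 2

This account rests on a few compounds, and the source may have more. Where it says the series, first, only, none or still open, it means among the compounds named here.

Compound 2 `COc1nc2ccc(Br)cc2cc1C(c1ccccc1)n1cc(-c2ccccc2)nn1` gives the highest of three numbers in an ADME assay on PANC-1 cells (Homo sapiens) for cytotoxicity, read by sulforhodamine B assay, with a stated time of 48 h, tested at 10 uM (on this read-out higher numbers stand for more inhibition at the one concentration tested (going by the name of the read-out) and lower numbers for less inhibition), with 30.1%. Compound 1 `CCCCCCc1cn(C(c2ccccc2)c2cc3cc(Br)ccc3nc2OC)nn1` gives 6.08%, and compound 3 `CCCCCCCCc1cn(C(c2ccccc2)c2cc3cc(Br)ccc3nc2OC)nn1` gives 12.1%. The step of a number 24 percentage points higher from compound 1 to compound 2 (beyond the scatter) and the step of a number 18 percentage points lower from compound 2 to compound 3 (beyond the scatter) both show that phenyl on the aromatic carbon goes with the higher number, while hexyl or octyl there goes with a lower number. Compound 4 `COc1nc2ccc(Br)cc2cc1C(c1ccccc1)n1cc(CCCO)nn1` differs from compound 2 by 3-hydroxypropyl in place of phenyl on an aromatic carbon. Because the step of a number 18 percentage points lower from compound 2 to compound 3 (beyond the scatter) shows a chain in place of phenyl lowering the number, a step of a number 20.1 percentage points lower from compound 2 to compound 4 (beyond the scatter) is expected here. Compound 4 is therefore estimated to give about 10%, within 0% to 25%, in this assay.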

Compound 4, a percentage reported as inhibition, at one concentration (the size of the read-out at that concentration, not a potency): 25.5%
For compound 4 the middle estimate is 15.5 percentage points below the measured one; measured number outside the range, above it.
By their numbers in this assay, from the lowest: compounds 1 and 3 (each within the scatter of the next); then compounds 4 and 2 (each within the scatter of the next).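

In this assay a chain on this aromatic carbon does not by itself lower the number, since 3-hydroxypropyl in place of phenyl gives a number 4.6 percentage points lower from compound 2 to compound 4 (within the scatter) and so stays level with phenyl. The hydroxy group sets this chain apart from the plain chains, with a number 19.4 percentage points higher from compound 1 to compound 4 (beyond the scatter) and a number 13.4 percentage points higher from compound 3 to compound 4 (beyond the scatter) when set against hexyl and octyl. Among these compounds, lower numbers at this position go with hexyl and octyl, not with chains as such.

From the compounds shown here alone, whether an amine or a carboxylic acid in place of the hydroxy would hold the number stays open. Nothing available explains the gap between the hydroxy chain and the plain chains.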